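The compounds below may be only part of what the source reports. "The series", "measured", "known", "first", "only" and "open" are said of these compounds alone.

Measured so far in an assay on isolated protein for inhibition of lysosomal alpha-glucosidase (Rattus norvegicus), read by colorimetric assay; on this read-out lower numbers stand for stronger inhibition and higher numbers for weaker inhibition:
- compound 1, `OC[C@@]1(c2c(F)c(F)c(F)c(F)c2F)NC[C@@H](O)[C@@H]1O`: 66000 nM
- compound 2, `OC[C@@]1(c2cccc(F)c2)NC[C@@H](O)[C@@H]1O`: 216000 nM
- compound 3, `OC[C@]1(c2cccc(F)c2)NC[C@H](O)[C@H]1O`: 43000 nM

Compound 2 gives the highest number of the three and thus the weakest inhibition; compound 1 lies nearer to it and compound 3 furthest, and both gaps stand beyond the scatter. Among the compounds with values here, the only measured step that changes a single thing is a 5.0-fold lower number from compound 2 to compound 3 (0.70 log units; beyond the scatter), and it rests on (the fact that compounds 2 and 3 differ only in the configuration as drawn); it is a change of configuration alone and leaves every substituent on the aromatic ring untouched.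

Compound 4, `OC[C@@]1(c2ccccc2)NC[C@@H](O)[C@@H]1O`, is not yet measured. It differs from compound 2 by hydrogen in place of fluoro on an aromatic carbon. Within the data shown here, no measured step exchanges a fluoro for hydrogen. Compound 1 differs from compound 2 in more than one place on the aromatic ring, so its lower number is only a loose hint and not a step that can be carried over. Among the measured compounds shown here, nothing among the measured compounds calls for a step beyond the scatter when the single fluoro is removed; the expectation is a number close to that of compound 2, with the uncertainty widened in both directions. The step from compound 2 to compound 4 is expected to be a 1.2-fold lower number from compound 2 to compound 4 (0.08 log units; within the scatter). Compound 4 is expected to give 180000 nM, within a range of 60000 nM to 500000 nM.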

Compound 4, half-maximal inhibitory concentration: 904000 nM
Compound 4: middle estimate off by 5.0-fold (0.70 log units), on the low side; measured number outside the range, above it.
By their numbers in this assay, from the lowest: compounds 3 and 1 (each within the scatter of the next); then compound 2; then compound 4.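

Exchanging fluoro for hydrogen on an aromatic carbon, meta to a group of 9 heavy atoms, gives in this assay a 4.2-fold higher number from compound 2 to compound 4 (0.62 log units; beyond the scatter). Within the data shown here, this is the first single-place step on the aromatic ring itself, and it shows that this one fluoro is not a silent passenger: compound 2 with the fluoro gives the lower number, and the hydrogen at this place weakens inhibition beyond the scatter, while the earlier single-place step, a 5.0-fold lower number from compound 2 to compound 3 (0.70 log units; beyond the scatter), spoke only to configuration. Nothing at hand on the configuration of the series accounts for the size or direction of this new step.

Open, on these data alone, is whether the link between the number and this position belongs to fluoro as such or would also appear with a chloro, a methoxy or an amine on the same aromatic carbon. Equally open, as far as these compounds go, is whether the exchange of fluoro for hydrogen would move the number in the same direction in the mirror-image configuration of compound 3.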